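Replacing 3-bromophenyl with 1H-benzimidazol-2-yl on the aromatic nitrogen

The source may report more compounds than this note shows. Statements on the series, on what has been measured and on what is new or still open speak of the compounds shown alone.

Measured in a functional assay on MCF7 cells (Homo sapiens) for cytotoxicity, read by sulforhodamine B assay, with a stated time of 48 h (a lower number here means a stronger inhibitor, a higher number a weaker inhibitor), as follows:
- compound 1 `N#Cc1cc(-c2ccccc2)n(Cc2nc3ccccc3[nH]2)c1N` gives 515 nM
- compound 2 `Nc1c(-c2nc3ccccc3[nH]2)cc(-c2ccccc2)n1-c1cccc(Br)c1` gives 2120 nM

Compound 2 at 2120 nM holds the higher of the two numbers, and its gap to compound 1 at 515 nM lies beyond the scatter. These two compounds differ in more than one place, so the gap belongs to no single change.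

Compound 3 `Nc1c(-c2nc3ccccc3[nH]2)cc(-c2ccccc2)n1-c1nc2ccccc2[nH]1` keeps the core of compound 2 and carries 1H-benzimidazol-2-yl in place of 3-bromophenyl on an aromatic nitrogen with the rest unchanged. Among the measured compounds shown here, no measured step covers this change. For the measured compounds named here, the only lower number in hand is that of compound 1 at 515 nM and its group on that nitrogen also contains 1H-benzimidazol-2-yl, so a move toward a lower number in this assay is expected, though two values give thin support. The estimated step is a 2.1-fold lower number from compound 2 to compound 3 (0.33 log units; beyond the scatter) and it is expected to be modest, near the edge of the scatter. In this assay the expected value for compound 3 is 1000 nM with 300 nM to 3500 nM as the estimated range.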

Compound 3, half-maximal inhibitory concentration: 1620 nM
The estimate for compound 3 lay 1.6-fold (0.21 log units) below the measured number; the range from low to high includes it.
By their numbers in this assay, from the lowest: compound 1; then compounds 3 and 2 (each within the scatter of the next).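

In this assay, 1H-benzimidazol-2-yl in place of 3-bromophenyl on the aromatic nitrogen gives a 1.3-fold lower number from compound 2 to compound 3 (0.12 log units; within the scatter), so on this nitrogen, next to the ring atom that bears a phenyl group, the two groups are not told apart, even though the entering group brings 1 hydrogen-bond donor and 1 hydrogen-bond acceptor and the leaving group brings neither. Compound 1 at 515 nM differs from compound 3 in more than one place, so its value cannot be assigned to the 1H-benzimidazol-2-yl group or to any other single change, and the steps linking it to the other two compounds cannot be read. Nothing measured on these compounds speaks to why this step falls within the scatter.

As far as these compounds go, whether a methyl group or a short chain ending in an amine on this nitrogen would give a step beyond the scatter remains open. Also open, from the compounds shown here alone, is how much a carboxylic acid in place of the 1H-benzimidazol-2-yl group on the carbon two ring bonds from this nitrogen would change the number with the rest held fixed.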